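From 4-fluorophenyl to furan-2-yl on a thin record

A few compounds are considered here, and "the series" means these few. Any claim that something is new, unique, unknown or untested is made for them only; others in the source may bear on it.

Three compounds on the shared core have entries in a functional assay on 1A9 cells (Homo sapiens) for cytotoxicity (on this read-out lower numbers stand for an effect already at smaller amounts and higher numbers for an effect only at larger amounts of compound), but only one of them carries a number. Compound 1 (`COC1=C(C)C(=O)/C(=C(O)/C=C/c2ccc(F)cc2)C(=O)C1(C)C`) has no single value to stand on, since its entry reads "not determined" (no result reported) in this record. Compound 3 (`COC1=C(C)C(=O)/C(=C(O)/C=C/c2cccc3ccccc23)C(=O)C1(C)C`) is in the same position, with "not determined" (no result reported) as its entry. Among the measured compounds shown here, compound 2 (`COC1=C(C)C(=O)/C(=C(O)/C=C/c2c(C)cc(C)cc2C)C(=O)C1(C)C`) gives 6.2 ug/mL as the only measured value.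

Compound 4 (`COC1=C(C)C(=O)/C(=C(O)/C=C/c2ccco2)C(=O)C1(C)C`) has not yet been measured. The structural change that leads to it is as follows: furan-2-yl in place of 4-fluorophenyl on a double-bonded chain carbon bound to a double-bonded chain carbon. For the measured compounds named here, no measured step between these compounds offers a guide to the size of such a swap. No shift beyond the usual scatter is therefore expected in this assay, and no direction can be argued from the data. Going by the values given here, the sole anchor is compound 2 at 6.2 ug/mL on the same core, and one value leaves the expectation wide. For compound 4 the estimated value is 6 ug/mL with an expected range from 2 ug/mL to 18 ug/mL as its bounds.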

Compound 4, concentration for half-maximal effect: 7.9 ug/mL
The estimate for compound 4 lay 1.3-fold (0.12 log units) below the measured number, and the stated range covers the measured number.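

In this assay, among the compounds shown here, compound 4 gives 7.9 ug/mL, but compound 1 has no single number, so no step from compound 1 to compound 4 can be read. No available evidence bears on the value of compound 4. The compounds shown leave open whether furan-2-yl in place of 4-fluorophenyl changes the cytotoxicity read-out on the shared core, and in which direction.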